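A few compounds are considered here, and "the series" means these few. Any claim that something is new, unique, unknown or untested is made for them only; others in the source may bear on it.

Of the compounds shown here, three have been measured in a functional assay on HGC-27 cells (Homo sapiens) for inhibition, read by MTT assay, with a stated time of 72 h; a higher number here means a weaker inhibitor, a lower number a stronger inhibitor.
Compound 1 `Cc1cc(N2CC[C@@H](C)[C@@H](N(C)c3ncnc4[nH]ccc34)C2)n2nc(SCc3nc4ccccc4[nH]3)nc2n1` gives > 100000 nM, which is a limit of the assay and not a number.
Compound 2 `Cc1cc(N2CC[C@@H](C)[C@@H](N(C)c3ncnc4[nH]ccc34)C2)n2nc(SCc3ccccc3Br)nc2n1` gives 21300 nM.
Compound 3 `Cc1cc(N2CC[C@@H](C)[C@@H](N(C)c3ncnc4[nH]ccc34)C2)n2nc(SCc3ccc([N+](=O)[O-])cc3)nc2n1` gives 29400 nM.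

Going by these compounds, compound 1 therefore stands only at a limit (the limit of > 100000 nM in this assay, at which 1 of the 3 values shown sits), so its true value is unknown. Compound 4 `Cc1cc(N2CC[C@@H](C)[C@@H](N(C)c3ncnc4[nH]ccc34)C2)n2nc(SCc3ccc(C(F)(F)F)cc3)nc2n1` differs from compound 1 in one place: 4-(trifluoromethyl)phenyl in place of 1H-benzimidazol-2-yl on a saturated chain carbon bound to a sulfur. Two measured steps start from compound 1 and also replace the same group with a substituted phenyl: an at least 4.6-fold lower number from compound 1 to compound 2 (0.67 log units; beyond the scatter) and an at least 3.4-fold lower number from compound 1 to compound 3 (0.53 log units; beyond the scatter). The two products lie close together, as a 1.4-fold higher number from compound 2 to compound 3 (0.14 log units; within the scatter) shows. By analogy with those steps, compound 4 is expected to give a clearly lower number, an at least 4.0-fold lower number from compound 1 to compound 4 (0.60 log units; beyond the scatter). Compound 4 is thus estimated at 25000 nM, within a range from 9000 nM to 70000 nM.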

Compound 4, half-maximal inhibitory concentration: 9540 nM
Compound 4: middle estimate off by 2.6-fold (0.42 log units), on the high side; the measured number falls inside the stated range.
By their numbers in this assay, from the lowest: compound 4; then compounds 2 and 3 (each within the scatter of the next). At a limit, above all of these: compound 1.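

In this assay, the groups on the saturated chain carbon bound to a sulfur now separate: compounds 2 and 3 lay within the scatter of each other, but trifluoromethyl in place of nitro on an aromatic carbon gives a 3.1-fold lower number from compound 3 to compound 4 (0.49 log units; beyond the scatter), and 4-(trifluoromethyl)phenyl in place of 2-bromophenyl gives a 2.2-fold lower number from compound 2 to compound 4 (0.35 log units; beyond the scatter). Replacing 1H-benzimidazol-2-yl with 4-(trifluoromethyl)phenyl gives an at least 10-fold lower number from compound 1 to compound 4 (1.02 log units; beyond the scatter). That step is only a bound, as compound 1 stands at a limit: the limit of > 100000 nM in this assay, at which 1 of the 4 values shown sits.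

Compounds 2 and 4 differ in both the substituent and its place on the phenyl ring, so the effects of these two differences cannot be separated. Going by these compounds, how an amine or a carboxylic acid on that phenyl ring would read stays open.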